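Swapping the ring on the sulfonyl sulfur of compound 3

A few compounds are considered here, and "the series" means these few. Any claim that something is new, unique, unknown or untested is made for them only; others in the source may bear on it.

The compounds here share one core and differ only in the aromatic group attached to the sulfonyl sulfur. Compound 1 `CCN(Cc1ccccc1)C(=O)C1CCN(S(=O)(=O)c2ccccc2)CC1` carries a plain benzene ring there; in a functional assay on CHO cells for positive allosteric modulation of muscarinic acetylcholine receptor M5 (Homo sapiens), read by calcium flux (a higher number here means a larger maximal response, a lower number a smaller maximal response), compound 1 gives 69%. Compound 2 `CCN(Cc1ccccc1)C(=O)C1CCN(S(=O)(=O)c2ccc(OC)cc2)CC1` has a methoxy in place of hydrogen on an aromatic carbon of that ring, and in this assay compound 2 gives 84%, a step that is a number 15 percentage points higher from compound 1 to compound 2 (beyond the scatter).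

Compound 3 `CCN(Cc1ccccc1)C(=O)C1CCN(S(=O)(=O)c2cccnc2)CC1` carries a pyridin-3-yl group on the sulfonyl sulfur, but for compound 3 the result in this assay is "not determined" (no result reported), so compound 3 offers no number of its own to stand on. Compound 4 `CCN(Cc1ccccc1)C(=O)C1CCN(S(=O)(=O)c2ccc3occc3c2)CC1` is obtained from compound 3 by the change (1-benzofuran-5-yl in place of pyridin-3-yl on a sulfonyl sulfur).

Within the data shown here, no measured step shows one aromatic ring replaced by another on the sulfonyl sulfur. Among the measured compounds shown here, the single step that exists, a number 15 percentage points higher from compound 1 to compound 2 (beyond the scatter), concerns only a methoxy added to a benzene ring, and it is a loose guide at best; it shows that a small change at this position can move the maximal response by a modest amount, beyond the scatter. For the measured compounds named here, since compound 3 has no value, no step into compound 4 can be sized. Compound 4 is therefore expected to give about 75% in this assay, with an estimated range from 55% to 95%.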

Compound 4, largest response reached (reported as percent of maximum), in percent of the reference or control that the assay uses: 80%
Beside the measured number, compound 4's estimate is 5 percentage points below it, within the range that was stated.
By their numbers in this assay, from the lowest: compound 1; then compounds 4 and 2 (each within the scatter of the next).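

On the sulfonyl sulfur, a group of two aromatic rings can stand in for a single ring without losing the maximal response in this assay: 1-benzofuran-5-yl in place of phenyl gives a number 11 percentage points higher from compound 1 to compound 4 (beyond the scatter). With 1-benzofuran-5-yl in place of 4-methoxyphenyl, the result is a number 4 percentage points lower from compound 2 to compound 4 (within the scatter), so these two groups cannot be told apart here, and the methoxy group is no longer the only change shown to lift the response over plain phenyl. Nothing available here explains why these two different groups give such similar results.

As far as these compounds go, the step from compound 3 to compound 4 cannot be read, as compound 3 has no number, so it remains open how pyridin-3-yl, with its ring nitrogen, compares with any of the other groups. Also open, from the compounds shown here alone, is how the maximal response would move with an amine or a carboxylic acid on the aromatic ring, or with a plain alkyl chain on the sulfonyl sulfur in place of an aromatic ring.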